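Replacing the 2-methyl-1H-imidazol-1-yl group of compound 1

The compounds below may be only part of what the source reports. "The series", "measured", "known", "first", "only" and "open" are said of these compounds alone.

Of the compounds shown here, two have been measured in a physicochemical assay for lipophilicity, using the shake flask method, in phosphate buffer, measured as octanol-water partition, with a stated time of 30 min, at pH 7.4 (on this read-out higher numbers stand for higher lipophilicity and lower numbers for lower lipophilicity), so far.

Compound 1 `Cc1nccn1-c1cnc(NCc2c(F)ccc3c2CCO3)c2cn[nH]c(=O)c12` gives 2.1
Compound 2 `C[C@@H]1CC(=O)N(c2cnc(NCc3c(F)ccc4c3CCO4)n3cnnc23)C1` gives 1.8

Among the compounds with values here, compound 1 and compound 2 lie within the scatter of each other, and they do not differ in just one place, so no measured step is available as a guide. Compound 3 `Cc1nc(CO)ccc1-c1cnc(NCc2c(F)ccc3c2CCO3)c2cn[nH]c(=O)c12` carries 6-(hydroxymethyl)-2-methylpyridin-3-yl in place of 2-methyl-1H-imidazol-1-yl on an aromatic carbon of the core of compound 1 (6-(hydroxymethyl)-2-methylpyridin-3-yl in place of 2-methyl-1H-imidazol-1-yl on an aromatic carbon). In this assay the estimated step, a number 0.10 log units higher from compound 1 to compound 3 (within the scatter), is expected to be upward but to stay within the scatter. Compound 3 is expected at 2.2 (estimated range 1.7 to 2.7).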

Compound 3, distribution coefficient: 2.4
The estimate for compound 3 lay 0.20 log units below the measured number; the measured number falls inside the stated range.
By their numbers in this assay, from the lowest: compounds 2, 1 and 3 (each within the scatter of the next, the first and the last beyond it).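

Within the data shown here, on an aromatic carbon para to a large group, the first exchange that can be read in one place puts 6-(hydroxymethyl)-2-methylpyridin-3-yl in place of 2-methyl-1H-imidazol-1-yl. In this assay this amounts to a number 0.30 log units higher from compound 1 to compound 3 (within the scatter) even though the six-membered ring with its hydroxymethyl replaces a smaller five-membered ring. Nothing available explains this result.

This single exchange cannot separate the contributions of the ring and the hydroxymethyl. Going by these compounds, whether an amine or a carboxylic acid at this position would also stay within the scatter remains open.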